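3,4-Dimethoxyphenyl for 3,4-dihydroxyphenyl on compound 2

The source may hold more compounds than are shown below. What is called first, only, known or untested is meant among the compounds shown, and "the series" means these compounds.

- compound 1 `COc1ccc(Oc2ccc(C(C)C)cc2-c2ccsc2S(=O)(=O)NCCNC(=O)Nc2cc(Cl)cc(Cl)c2)cc1OC` gives 9000 nM
- compound 2 `Cc1ccc(-c2ccsc2S(=O)(=O)NCCNC(=O)Nc2cc(C(F)(F)F)cc(C(F)(F)F)c2)c(Oc2ccc(O)c(O)c2)c1` gives 5600 nM
- compound 3 `O=C(NCCNS(=O)(=O)c1sccc1-c1ccccc1Oc1ccc(O)c(O)c1)Nc1cc(C(F)(F)F)cc(C(F)(F)F)c1` gives 4900 nM

All three values come from a functional assay on RS4-11 cells (Homo sapiens) for inhibition, read by CCK-8 assay, with a stated time of 48 h (a lower number here means a stronger inhibitor, a higher number a weaker inhibitor), and stand close together. Compound 2 at 5600 nM is not separated from the other two, since compound 1 and compound 3 both lie within the scatter of it.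

The next compound is compound 4 `COc1ccc(Oc2cc(C)ccc2-c2ccsc2S(=O)(=O)NCCNC(=O)Nc2cc(C(F)(F)F)cc(C(F)(F)F)c2)cc1OC`. Its change from compound 2 is 3,4-dimethoxyphenyl in place of 3,4-dihydroxyphenyl on an oxygen on an aromatic ring and reads in words as 3,4-dimethoxyphenyl in place of 3,4-dihydroxyphenyl on an oxygen on an aromatic ring.

Among the compounds with values here, no measured step covers this change. Within the data shown here, the only step available is a 1.1-fold lower number from compound 2 to compound 3 (0.06 log units; within the scatter) for hydrogen in place of methyl on an aromatic carbon, which concerns another place in the structure. Compound 1 does carry the 3,4-dimethoxyphenoxy group and gives 9000 nM in this series, but it differs from compound 2 elsewhere too, so it offers only indirect support. No step beyond the scatter is therefore expected in this assay, and no direction can be argued with confidence.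

The expected change is a 1.2-fold higher number from compound 2 to compound 4 (0.06 log units; within the scatter) and remains a weakly supported estimate.

For compound 4 the estimated value is 6500 nM with an expected range from 2500 nM to 16000 nM in this readout.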

Compound 4, half-maximal inhibitory concentration: 5600 nM
For compound 4 the middle estimate is 1.2-fold (0.06 log units) above the measured one, within the range that was stated.
By their numbers in this assay, from the lowest: compounds 3, 2, 4 and 1 (each within the scatter of the next).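

The swap of 3,4-dihydroxyphenyl for 3,4-dimethoxyphenyl, on an oxygen on an aromatic ring, now has a direct reading in this assay, with no change at the digits printed from compound 2 to compound 4 (within the scatter). The hydrogen-bond donors counted on the 3,4-dihydroxyphenyl group are absent from the 3,4-dimethoxyphenyl group, yet this pair shows no separation in this readout, a reading that compound 1 could not give, as it carries the 3,4-dimethoxyphenoxy group but differs from compound 2 in other places as well. No measurement at hand accounts for this result, so the pair records the outcome without giving a reason for it.

Open, on these data alone, is whether a larger departure at this position, such as a carboxylic acid, an amine or a longer alkoxy chain on the phenyl ring in place of the two methoxy groups, would move the value in this assay beyond the scatter. Also open, as far as these compounds go, is whether the same swap reads the same way on the core of compound 3, which has hydrogen in place of the methyl group on an aromatic carbon.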